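A few compounds are considered here, and "the series" means these few. Any claim that something is new, unique, unknown or untested is made for them only; others in the source may bear on it.

The measured compounds in a functional assay on NCI-H460 cells (Homo sapiens) for antiproliferative activity, read by CCK-8 assay, with a stated time of 72 h, tested at 8 uM; a lower number here means a weaker effect, a higher number a stronger effect of the compound at the concentration tested:
compound 1 `Nc1ccccc1NC(=O)c1ccc(Cn2cnc3c(Nc4ccccc4)nc(Cl)nc32)cc1`: 77.8%
compound 2 `Nc1ccccc1NC(=O)c1ccc(Cn2cnc3c(NCc4ccccc4)nc(Cl)nc32)cc1`: 61.2%
compound 3 `Nc1ccccc1NC(=O)c1ccc(Cn2cnc3c(Nc4cccc(OC(F)(F)F)c4)nc(Cl)nc32)cc1`: 62.4%

Compound 3 stands second of the three. Its nearest neighbour is compound 2, with a number 1.2 percentage points higher from compound 2 to compound 3 (within the scatter), a gap within the scatter; its furthest is compound 1, from which a number 15.4 percentage points lower from compound 1 to compound 3 (beyond the scatter). The other measured step is a number 16.6 percentage points lower from compound 1 to compound 2 (beyond the scatter).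

Compound 4 `CC1CCN(c2nc(Cl)nc3c2ncn3Cc2ccc(C(=O)Nc3ccccc3N)cc2)CC1` has not yet been measured in this assay. It differs from compound 3 in one place: 4-methylpiperidin-1-yl in place of (3-(trifluoromethoxy)phenyl)amino on an aromatic carbon.

Among the compounds with values here, none of the measured steps replaces the amino-linked aromatic ring with a non-aromatic amine, so no step bears on this change directly. What the measured steps do show is that altering the group at this position moved the number only modestly, as in the step from compound 1 to compound 2 and the step from compound 1 to compound 3, while compound 2 and compound 3 sit within the scatter of each other. For compound 4 the expected step is therefore a number 7.4 percentage points lower from compound 3 to compound 4 (within the scatter), a change not clearly beyond the scatter. Compound 4 is estimated at 55%, in a range from 35% to 75%.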

Compound 4, a percentage reported as inhibition, at one concentration (the size of the read-out at that concentration, not a potency): 40.9%
For compound 4 the middle estimate is 14.1 percentage points above the measured one, within the range that was stated.
By their numbers in this assay, from the lowest: compound 4; then compounds 2 and 3 (each within the scatter of the next); then compound 1.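

In this assay the 4-methylpiperidin-1-yl group at this position stands clearly apart from all three amino-linked groups, with steps that are beyond the scatter each time (a number 21.5 percentage points lower from compound 3 to compound 4 (beyond the scatter)) and (a number 20.3 percentage points lower from compound 2 to compound 4 (beyond the scatter)) and the largest from the anilino group (a number 36.9 percentage points lower from compound 1 to compound 4 (beyond the scatter)). The earlier compounds shown here varied only groups joined through an amino nitrogen and bearing an aromatic ring, whereas this change brings in a non-aromatic ring with 0 hydrogen-bond donors and gives the lowest number of the four. No measurement at hand ties this difference to any property of these groups.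

The compounds shown do not separate the loss of the aromatic ring from the loss of the amino hydrogen. A cyclohexylamino group and an N-methylanilino group at the same carbon would bear on each in turn.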